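This account rests on a few compounds, and the source may have more. Where it says the series, first, only, none or still open, it means among the compounds named here.

Measured in an ADME assay on J774 cells (Mus musculus) for cytotoxicity, read by fluorescence and resazurin assay, with a stated time of 24 h (on this read-out higher numbers stand for lower toxicity in this test and lower numbers for higher toxicity in this test), so far:

Compound 1 `O=[N+]([O-])c1ccc(S(=O)(=O)Nc2ccc3nccnc3c2)cc1` gives >= 300000 nM, which is a limit of the assay and not a number.
Compound 2 `O=S(=O)(Nc1ccc2nccnc2c1)c1ccc(Cl)cc1` gives 23800 nM.
Compound 3 `Cc1cc2cc(NS(=O)(=O)c3ccc([N+](=O)[O-])cc3)ccc2[nH]1` gives 132000 nM.

Compound 2 differs from compound 1 by chloro in place of nitro on an aromatic carbon. In this assay this change made an at least 12-fold lower number from compound 1 to compound 2 (1.10 log units; beyond the scatter); the size is known only as a bound because of the limit of >= 300000 nM in this assay, at which 1 of the 3 values shown sits. Compound 3 rests on a different core from compound 1, and the difference between the two cores is not broken down here. Among the two plain numbers, compound 3 stands highest, with compound 2 nearest to it.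

Compound 4 `Cc1cc2cc(NS(=O)(=O)c3ccc(Cl)cc3)ccc2[nH]1` has not yet been measured. It differs from compound 3 by chloro in place of nitro on an aromatic carbon, the same change as between compound 1 and compound 2. In this assay the step from compound 3 to compound 4 is expected to be a 12-fold lower number from compound 3 to compound 4 (1.08 log units; beyond the scatter), resting on an at least 12-fold lower number from compound 1 to compound 2 (1.10 log units; beyond the scatter). Compound 4 is therefore estimated at 11000 nM, expected to lie between 4000 nM and 35000 nM.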

Compound 4, half-maximal cytotoxic concentration: 195000 nM
Beside the measured number, compound 4's estimate is 18-fold (1.25 log units) below it, outside the stated range (above it).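

In this assay, chloro in place of nitro on an aromatic carbon gave a 1.5-fold higher number from compound 3 to compound 4 (0.17 log units; within the scatter), so on the core of compound 3 the change moved the number by no more than the scatter. The change therefore did not carry over in size from the core of compound 1 to the core of compound 3: the same change on two cores in this assay, an at least 12-fold lower number (1.10 log units; beyond the scatter) from compound 1 to compound 2 and a 1.5-fold higher number (0.17 log units; within the scatter) from compound 3 to compound 4, at least 18-fold (1.27 log units) apart, beyond the scatter of two such steps This comparison rests on two cores only and does not show why they differ, and the earlier step is known only as a bound: the limit of >= 300000 nM in this assay, at which 1 of the 4 values shown sits.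

The compounds shown leave open how an amine or a carboxylic acid in place of nitro would behave on either core. They also leave open which of the two steps a third core would resemble.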